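The compounds below may be only part of what the source reports. "The series", "measured", "known", "first", "only" and "open" are said of these compounds alone.

Measured so far:
compound 1, `CNc1nc(N)nc2ccccc12`, gives 6.87 uM;
compound 2, `CCCCCNc1nc(N)nc2ccccc12`, gives 0.1 uM;
compound 3, `CC(C)CCNc1nc(N)nc2ccccc12`, gives 2.11 uM.

All three values come from an ADME assay on HEK293 cells for agonist activity at Toll-like receptor 8 (Homo sapiens), read by a luciferase reporter, with a stated time of 6 h; on this read-out lower numbers stand for an effect already at smaller amounts and higher numbers for an effect only at larger amounts of compound. Among these numbers compound 3 holds the second highest place; two measured steps fix its position, a 21-fold higher number from compound 2 to compound 3 (1.32 log units; beyond the scatter) and a 3.3-fold lower number from compound 1 to compound 3 (0.51 log units; beyond the scatter).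

Compound 4, `CCCC(C)Nc1nc(N)nc2ccccc12`, has the same atoms as compound 3, joined differently: 1-methylbutyl in place of isopentyl on a nitrogen on an aromatic ring.

Among the compounds with values here, three measured steps bear on this change. a 69-fold lower number from compound 1 to compound 2 (1.84 log units; beyond the scatter) shows that a chain with no branch brings a large gain. a 3.3-fold lower number from compound 1 to compound 3 (0.51 log units; beyond the scatter) shows that a branched chain brings only a modest gain. a 21-fold higher number from compound 2 to compound 3 (1.32 log units; beyond the scatter) shows how much a branch near the end of the chain costs. Within the data shown here, compound 4 keeps a branch but moves it, so that a longer unbranched run remains; no measured pair isolates exactly this move, so the expectation is uncertain. A clearly lower number than compound 3, though not as low as compound 2, is expected, a step of a 3.5-fold lower number from compound 3 to compound 4 (0.55 log units; beyond the scatter). Compound 4 is therefore estimated at 0.6 uM, within a range from 0.15 uM to 2.5 uM.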

Compound 4, minimum effective concentration: 0.17 uM
Beside the measured number, compound 4's estimate is 3.5-fold (0.55 log units) above it; the measured number falls inside the stated range.
By their numbers in this assay, from the lowest: compounds 2 and 4 (each within the scatter of the next); then compound 3; then compound 1.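

Moving the branch gives a 12-fold lower number from compound 3 to compound 4 (1.09 log units; beyond the scatter), even though isopentyl and 1-methylbutyl contain the same carbons, so on this nitrogen the arrangement of the chain matters and not just its size. A branch therefore does not always carry a large cost: compound 3 pays one, while compound 4 shows a 1.7-fold higher number from compound 2 to compound 4 (0.23 log units; within the scatter), which leaves it indistinguishable from the unbranched pentyl of compound 2. The branched chain of compound 4 also retains a large gain over the small methyl group, with a 40-fold lower number from compound 1 to compound 4 (1.61 log units; beyond the scatter).

Nothing available explains why these two branched chains behave so differently. Going by these compounds, it remains open whether a longer chain, a cyclopentyl ring or an amine at the end of the chain would keep the number this low.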